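Lengthening the chain of compound 3 toward compound 4

The compounds below may be only part of what the source reports. "The series", "measured", "known", "first", "only" and "open" are said of these compounds alone.

compound 1 `O=C(CCCCCCCCCCCc1ccccc1)CC(=O)N[C@H]1CCOC1=O` gives 4000 nM
compound 2 `O=C(CCCCCCCCCc1ccccc1)CC(=O)N[C@@H]1CCOC1=O` gives > 100000 nM as a limit
compound 3 `O=C(CCCCCCCc1ccccc1)CC(=O)N[C@H]1CCOC1=O` gives 2000 nM

In a functional assay on PC-3 cells (Homo sapiens) for cytotoxicity, read by sulforhodamine B assay, with a stated time of 5 days (a lower number here means a stronger inhibitor, a higher number a weaker inhibitor), compound 3 and compound 1 lie within the usual scatter of each other, so neither stands apart from the other. For compound 2 there is only a limit, > 100000 nM and no number.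

Compound 4 `O=C(CCCCCCCCCc1ccccc1)CC(=O)N[C@H]1CCOC1=O` has not yet been measured. Its change from compound 3 is phenethyl in place of phenyl on a saturated chain carbon, seven bonds along the chain from a carbonyl carbon and reads in words as phenethyl in place of phenyl on a saturated chain carbon, seven bonds along the chain from a carbonyl carbon. For the measured compounds named here, no measured step exists to size this change directly. With compound 3 at 2000 nM and compound 1 at 4000 nM as the nearest numbers, no shift beyond the scatter is expected in this assay in either direction. The estimated change, a 1.5-fold higher number from compound 3 to compound 4 (0.18 log units; within the scatter) stays within that scatter. Compound 4 is expected at 3000 nM with an estimated range of 1000 nM to 10000 nM for its value.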

Compound 4, half-maximal inhibitory concentration: 4000 nM
Beside the measured number, compound 4's estimate is 1.3-fold (0.12 log units) below it; low and high end bracket the measured number.
By their numbers in this assay, from the lowest: compounds 3, 1 and 4 (each within the scatter of the next). At a limit, above all of these: compound 2.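

In this assay, phenethyl in place of phenyl on a saturated chain carbon, seven bonds along the chain from a carbonyl carbon, does little: a 2.0-fold higher number from compound 3 to compound 4 (0.30 log units; within the scatter), and no change at the digits printed from compound 1 to compound 4 (within the scatter), so the chain lengths of compounds 3, 4 and 1 are not told apart here. Compound 4 also gives compound 2 a partner of the same atoms and bonds, and the step is large, an at least 25-fold lower number from compound 2 to compound 4 (1.39 log units; beyond the scatter), with the stereocentre at a saturated ring carbon as the only difference: the fact that compounds 2 and 4 differ only in the configuration as drawn. Compound 2 is known only as a limit: the limit of > 100000 nM in this assay, at which 1 of the 4 values shown sits.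

The compounds shown leave open whether a chain shorter than in compound 3, or longer than in compound 1, would stay in this range, and whether an amine or a carboxylic acid in place of the phenyl would be tolerated. They also leave open whether the gap between the two configurations holds at other chain lengths.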